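The compounds below may be only part of what the source reports. "The series", "measured", "known", "first", "only" and "open" are said of these compounds alone.

Three compounds share one core and differ only in the group on the aromatic carbon next to the ring sulfur. Compound 1 `COc1cc(C(=O)c2sc(-c3cccs3)cc2N)cc(OC)c1OC` carries thiophen-2-yl there, and in a functional assay on L1210 cells (Mus musculus) for antiproliferative activity (on this read-out lower numbers stand for stronger inhibition and higher numbers for weaker inhibition), compound 1 gives 9.8 nM. Compound 2 `COc1cc(C(=O)c2sc(-c3ccc(Cl)c(Cl)c3)cc2N)cc(OC)c1OC` carries 3,4-dichlorophenyl, and in this assay compound 2 gives 260 nM. Compound 3 `COc1cc(C(=O)c2sc(-c3ccncc3)cc2N)cc(OC)c1OC` carries pyridin-4-yl, and in this assay compound 3 gives 1810 nM, the highest of the three numbers. Both a 7.0-fold higher number from compound 2 to compound 3 (0.84 log units; beyond the scatter) and a 180-fold higher number from compound 1 to compound 3 (2.27 log units; beyond the scatter) lie beyond the scatter, so compound 3 is the weakest inhibitor of the three.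

Compound 4 `COc1cc(C(=O)c2sc(-c3ccccc3Cl)cc2N)cc(OC)c1OC` is not yet measured. 2-chlorophenyl in place of pyridin-4-yl on an aromatic carbon The step of a 7.0-fold higher number from compound 2 to compound 3 (0.84 log units; beyond the scatter) bears most on this change: compound 2 carries 3,4-dichlorophenyl on the same aromatic carbon, and read in reverse that step points to a lower number for compound 4. The step of a 27-fold higher number from compound 1 to compound 2 (1.42 log units; beyond the scatter) shows that 3,4-dichlorophenyl still gave a far higher number than thiophen-2-yl, so compound 4 is not expected to reach compound 1. The expected step is therefore a 6.0-fold lower number from compound 3 to compound 4 (0.78 log units; beyond the scatter), towards a lower number. Compound 4 is estimated at 300 nM, with a range from 60 nM to 1500 nM.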

Compound 4, half-maximal inhibitory concentration: 20 nM
Estimate against measurement, compound 4: 15-fold (1.18 log units) above; measured number below the stated range.
By their numbers in this assay, from the lowest: compound 1; then compound 4; then compound 2; then compound 3.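

With 2-chlorophenyl, this position is shown to accept a six-membered aromatic ring of carbon only and still give a number near that of thiophen-2-yl in this assay: a 2.0-fold higher number from compound 1 to compound 4 (0.31 log units; beyond the scatter) is a modest step, though it lies beyond the scatter. Chlorine on a phenyl ring does not by itself set the number, as a 13-fold lower number from compound 2 to compound 4 (1.11 log units; beyond the scatter) separates 2-chlorophenyl from 3,4-dichlorophenyl, although these two groups differ in both the number and the placing of their chlorines, so the two differences cannot be told apart here. Within the data shown here, replacing pyridin-4-yl with 2-chlorophenyl, a 91-fold lower number from compound 3 to compound 4 (1.96 log units; beyond the scatter), covers most of the range seen at this position so far, so the choice of six-membered ring here can move the number a long way.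

Nothing available here explains why these groups give such different numbers. As far as these compounds go, it also remains open whether a methyl or methoxy group in place of the chlorine of 2-chlorophenyl would keep the number as low, and whether a single chlorine placed elsewhere on the phenyl ring would do the same.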